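Drawing Both Ring Stereocentres of Compound 1 as R

The source may report more compounds than this note shows. Statements on the series, on what has been measured and on what is new or still open speak of the compounds shown alone.

Compound 1 `CS(=O)(=O)NC(=O)c1ccc(C2CC2c2ccc(OCc3c(-c4c(Cl)cccc4Cl)noc3C3CC3)cc2Cl)cc1` is the stronger of the two measured compounds: in an assay on HEK293 cells for agonist activity at Bile acid receptor (Homo sapiens) (on this read-out lower numbers stand for an effect already at smaller amounts and higher numbers for an effect only at larger amounts of compound), compound 1 gives 44 nM, while compound 2 `O=C(NCCS(=O)(=O)O)c1ccc(C2CC2c2ccc(OCc3c(-c4c(Cl)cccc4Cl)noc3C3CC3)cc2Cl)cc1` gives 1370 nM, a step of a 31-fold higher number from compound 1 to compound 2 (1.49 log units; beyond the scatter). Compound 3 `CS(=O)(=O)NC(=O)c1ccc([C@@H]2C[C@H]2c2ccc(OCc3c(-c4c(Cl)cccc4Cl)noc3C3CC3)cc2Cl)cc1` differs from compound 1 only in how its stereocentres are drawn: the two compounds have the same atoms and bonds; at least one stereo element is drawn with a configuration in one of them and without one in the other: 2 of 2 stereo elements differ; a stereocentre at a saturated ring carbon is drawn without a configuration in compound 1 and R in compound 3; a stereocentre at a saturated ring carbon is drawn without a configuration in compound 1 and R in compound 3. Going by the values given here, the single measured step concerns a different change, the group on the amide nitrogen, so no measured step bears on defining the configuration. A single defined form may be the better or the poorer part of an undefined mixture. Compound 3 is therefore expected at 30 nM, within a range from 8 nM to 400 nM, the anticipated step being a 1.5-fold lower number from compound 1 to compound 3 (0.17 log units; within the scatter).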

Compound 3, half-maximal effective concentration: 44 nM
Compound 3: the middle estimate sits 1.5-fold (0.17 log units) below what was measured; low and high end bracket the measured number.
By their numbers in this assay, from the lowest: compounds 1 and 3 (each within the scatter of the next); then compound 2.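

In this assay, drawing both saturated ring carbons as R gives no change at the digits printed from compound 1 to compound 3 (within the scatter). The defined form therefore keeps the reading of the undefined drawing, and this position tolerates being fixed as R at both carbons without a step beyond the scatter. The pair differs in one respect only: the fact that one of compounds 1 and 3 is drawn with a defined configuration and the other without, at the place where they differ

The shown compounds leave open how the form with both ring carbons drawn as S would read, and whether compound 1 is a mixture at all. As far as these compounds go, a carboxylic acid in place of the methylsulfonyl amide on the defined form also remains open.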